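Dropping the sulfanyl side chain from compound 2

The source may hold more compounds than are shown below. What is called first, only, known or untested is meant among the compounds shown, and "the series" means these compounds.

In an ADME assay on GES1 cells (Homo sapiens) for inhibition, read by MTT assay, with a stated time of 72 h (a lower number here means a stronger inhibitor, a higher number a weaker inhibitor), compound 1 `Cc1cc(Nc2cc(-c3ccccc3)[nH]n2)n2nc(SCCCc3ccccc3)nc2n1` gives 40200 nM and compound 2 `Cc1cc(Nc2cc(-c3ccccc3)[nH]n2)n2nc(SCc3csc4ccccc34)nc2n1` gives 29200 nM, so compound 2 stands level with compound 1 within the scatter. Compound 3 `Cc1cc(Nc2cc(-c3ccccc3)[nH]n2)n2ncnc2n1` carries hydrogen in place of ((1-benzothiophen-3-yl)methyl)sulfanyl on an aromatic carbon. Among the measured compounds shown here, the only measured step, a 1.4-fold lower number from compound 1 to compound 2 (0.14 log units; within the scatter), exchanged the end of the side chain and stayed within the scatter. For the measured compounds named here, no measured compound lacks the side chain, so that step is only a weak guide. A modest expected move toward a higher number, a 2.1-fold higher number from compound 2 to compound 3 (0.31 log units; beyond the scatter), is assumed with wide uncertainty. For compound 3 the estimate is 60000 nM, with an expected range of 25000 nM to 150000 nM.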

Compound 3, half-maximal inhibitory concentration: > 50000 nM
Compound 3: no number, only a limit; the forecaster's own chance of this, stated with the estimate: 35%; the middle value does not contradict the limit.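

In this assay compound 3, with hydrogen on the aromatic carbon, gives a limit and not a number: the limit of > 50000 nM in this assay, at which 1 of the 3 values shown sits.

The steps read an at least 1.7-fold higher number from compound 2 to compound 3 (0.23 log units; that floor lies within the scatter) and an at least 1.2-fold higher number from compound 1 to compound 3 (0.09 log units; that floor lies within the scatter), so removing either sulfanyl side chain shows no move toward a lower number, though both floors stay within the scatter. The earlier step exchanged only the end of the side chain, whereas these steps remove the whole chain.

Going by these compounds, how far compound 3 lies past its limit stays open, so the size of the side chain's contribution cannot be read. On these data alone, the effect of an amine, a carboxylic acid or methylsulfanyl on this carbon also stays open.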